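Phenoxy extension in a series at its limit

This account rests on a few compounds, and the source may have more. Where it says the series, first, only, none or still open, it means among the compounds named here.

Measured in a functional assay on Jurkat cells (Homo sapiens); a higher number here means a weaker inhibitor, a lower number a stronger inhibitor:
- compound 1 `CC(C)[C@H](NC(=O)COc1cccc2ccccc12)C(=O)N[C@@H](CC(=O)O)C(=O)COc1ccc2ccccc2c1`: > 100000 nM
- compound 2 `CC(C)[C@H](NC(=O)COc1cccc2ccccc12)C(=O)N[C@@H](CC(=O)O)C(=O)COc1cccc(C(F)(F)F)c1`: > 100000 nM
- compound 3 `CC(C)[C@H](NC(=O)COc1cccc2ccccc12)C(=O)N[C@@H](CC(=O)O)C(=O)COc1ccc(C#N)cc1`: > 100000 nM

Compound 3 stands at a limit, > 100000 nM, and not at a number. The whole series shares this position: the limit of > 100000 nM in this assay, at which 3 of the 3 values shown sit.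

Compound 4 `CC(C)[C@H](NC(=O)COc1cccc2ccccc12)C(=O)N[C@@H](CC(=O)O)C(=O)COc1ccc(Oc2ccc(C(F)(F)F)cc2)cc1` carries this change: 4-(trifluoromethyl)phenoxy in place of cyano on an aromatic carbon.

Among the measured compounds shown here, three measured steps bear on it: a step that the two limits leave unreadable from compound 1 to compound 2, a step that the two limits leave unreadable from compound 1 to compound 3 and a step that the two limits leave unreadable from compound 2 to compound 3. None has a readable size, so neither a size nor a direction can be carried over to this assay. Compound 4 is expected to remain near the limit, most likely reported only as a limit.

The expected change is a number no higher from compound 3 to compound 4 (the limit leaves the size open).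

For compound 4 the estimated value is 100000 nM, with an expected range of 15000 nM to 200000 nM.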

Compound 4, half-maximal inhibitory concentration: 9300 nM
Compound 4: the middle estimate sits 11-fold (1.03 log units) above what was measured; measured number outside the range, below it.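

In this assay, the aromatic carbon that carried cyano proves able to move the read-out: 4-(trifluoromethyl)phenoxy in place of cyano gives an at least 10-fold lower number from compound 3 to compound 4 (1.03 log units; beyond the scatter). Among the compounds shown here, the steps among compound 1, compound 2 and compound 3 cannot be read, so this is the first size and direction available. Compound 4 is the only compound shown that stands off the limit: the limit of > 100000 nM in this assay, at which 3 of the 4 values shown sit.

As far as these compounds go, whether the step depends on the added aromatic ring, its trifluoromethyl group or the ether oxygen stays open. An unsubstituted phenoxy or a benzyl group on the same aromatic carbon would begin to separate these.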